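The source may report more compounds than this note shows. Statements on the series, on what has been measured and on what is new or still open speak of the compounds shown alone.

Three compounds share one core and differ only in the group attached to the carbonyl carbon. Compound 1 `COc1cc(-c2cc(/C=C/C(=O)c3ccc(N)cc3)[nH]n2)cc(OC)c1OC` gives 90% in a functional assay on SK-MEL-5 cells (Homo sapiens) for cytotoxicity, read by sulforhodamine B assay, with a stated time of 48 h, tested at 1 uM; a lower number here means a stronger effect, a higher number a weaker effect of the compound at the concentration tested. Compound 2 `COc1cc(-c2cc(/C=C/C(=O)c3ccc(Cl)c(Cl)c3)[nH]n2)cc(OC)c1OC` gives 94% in this assay, and compound 3 `COc1ccc(C(=O)/C=C/c2cc(-c3cc(OC)c(OC)c(OC)c3)n[nH]2)cc1OC` gives 91% in this assay. Compound 3 stands within the scatter of both companions: there is a number 1 percentage points higher from compound 1 to compound 3 (within the scatter) and a number 3 percentage points lower from compound 2 to compound 3 (within the scatter). The exchange of 3,4-dichlorophenyl for 4-aminophenyl on the carbonyl carbon was likewise a number 4 percentage points higher from compound 1 to compound 2 (within the scatter).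

Compound 4 `COc1ccc(C(=O)/C=C/c2cc(-c3cc(OC)c(OC)c(OC)c3)n[nH]2)cc1` differs from compound 3 by hydrogen in place of methoxy on an aromatic carbon. All three measured steps bear on this change, since each of them alters the group on the carbonyl carbon, and none of them reached beyond the scatter. Compound 4 is therefore expected to show no change at the digits printed from compound 3 to compound 4 (within the scatter) in this assay, that is, no step beyond the scatter. Compound 4 is estimated at 91% in this assay, with a range from 80% to 100%.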

Compound 4, a percentage reported as activity, at one concentration (the size of the read-out at that concentration, not a potency): 93%
For compound 4 the middle estimate is 2 percentage points below the measured one; the measured number falls inside the stated range.
By their numbers in this assay, from the lowest: compounds 1, 3, 4 and 2 (each within the scatter of the next).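

The earlier steps shown here exchanged the whole group on the carbonyl carbon, whereas this one takes a single methoxy off the 3,4-dimethoxyphenyl and leaves 4-methoxyphenyl, and in this assay it gives a number 2 percentage points higher from compound 3 to compound 4 (within the scatter). The 4-methoxyphenyl group also matches its other companions, with a number 1 percentage points lower from compound 2 to compound 4 (within the scatter) against 3,4-dichlorophenyl and a number 3 percentage points higher from compound 1 to compound 4 (within the scatter) against 4-aminophenyl. No measurement shown here offers an explanation for these small steps.

All the steps among these four compounds lie within the scatter at this one concentration, so it stays open whether any change at this place can move the number beyond it. Going by these compounds, it also stays open what a carboxylic acid or a dimethylamino group would give in place of the remaining methoxy, or a longer chain such as butoxy.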